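Carbonyl to secondary alcohol on the side chain of compound 2

This account rests on a few compounds, and the source may have more. Where it says the series, first, only, none or still open, it means among the compounds named here.

compound 1 `CC(C)[C@@H](O)C(=O)c1c[nH]c2ccccc12`: > 10000 nM
compound 2 `CC(C)(O)C(=O)Cc1cn([C@@H]2O[C@H](CO)[C@@H](O)[C@H](O)[C@H]2O)c2ccccc12`: > 10000 nM

Of the compounds shown here, two have been tested in a functional assay on BCG823 cells (Homo sapiens) for cytotoxicity, read by MTT assay; on this read-out higher numbers stand for weaker inhibition and lower numbers for stronger inhibition. Compound 1 `CC(C)[C@@H](O)C(=O)c1c[nH]c2ccccc12` returns only a limit of the assay, > 10000 nM. Compound 2 `CC(C)(O)C(=O)Cc1cn([C@@H]2O[C@H](CO)[C@@H](O)[C@H](O)[C@H]2O)c2ccccc12` likewise returns only a limit of the assay, > 10000 nM. Compound 2 thus stands at the limit of > 10000 nM in this assay, at which 2 of the 2 values shown sit, and the two values show no more than that neither compound reaches a measurable inhibition. Compound 3 `CC(C)(O)[C@@H](O)Cc1cn([C@@H]2O[C@H](CO)[C@@H](O)[C@H](O)[C@H]2O)c2ccccc12` differs from compound 2 by 1,2-dihydroxy-2-methylpropyl in place of (1-hydroxy-1-methylethyl)carbonyl on a saturated chain carbon bound to an aromatic carbon. Among the measured compounds shown here, no step between measured compounds is available to gauge this change. The expected step is a step that the limit leaves unreadable from compound 2 to compound 3, that is, none beyond the scatter, and it is most likely that this assay again reports only a limit. Compound 3 is accordingly estimated at 15000 nM, within a range from 5000 nM to 50000 nM.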

Compound 3, half-maximal inhibitory concentration: > 10000 nM
Compound 3: only a limit was reported; the forecaster's own chance of this, stated with the estimate: 85%; the middle value lies beyond the limit too.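

No step can be read between compound 2 and compound 3, because both return only a limit: the limit of > 10000 nM in this assay, at which 3 of the 3 values shown sit.

The compounds shown leave open whether 1,2-dihydroxy-2-methylpropyl in place of (1-hydroxy-1-methylethyl)carbonyl changes inhibition at all, and which structural change would bring a measurable value.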